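A few compounds are considered here, and "the series" means these few. Any claim that something is new, unique, unknown or untested is made for them only; others in the source may bear on it.

Measured so far:

compound 1 `CNC(=O)N1CCCc2ccc(NC(=O)c3cccc(-c4ccccc4)c3)cc21` — 1.39%
compound 2 `CNC(=O)N1CCCc2ccc(NC(=O)c3ccc(-c4ccn(C)n4)cc3)cc21` — 97%
compound 3 `CNC(=O)N1CCCc2ccc(NC(=O)c3ccc(-c4cn[nH]c4)cc3)cc21` — 98.3%

In a functional assay on MV4-11 cells (Homo sapiens) for antiproliferative activity, with a stated time of 6 days, tested at 6.25 uM (on this read-out lower numbers stand for a weaker effect and higher numbers for a stronger effect at the one concentration tested), compound 1 stands lowest of the three, far beneath compound 2 and compound 3, both of which carry a pyrazolyl group on the shared core instead of a phenyl. Compound 4 `CNC(=O)N1CCCc2ccc(NC(=O)c3cccc(-c4ccn(C(C)=O)n4)c3)cc21` takes the step (1-acetyl-1H-pyrazol-3-yl in place of phenyl on an aromatic carbon), placed meta to a large group. Among the compounds with values here, no measured step swaps phenyl for a pyrazolyl on its own; the only step within the pyrazolyl pair, a number 1.3 percentage points higher from compound 2 to compound 3 (within the scatter), shows the pyrazolyl variants lying close together in this assay. Since compound 1 gives 1.39% while compound 2 gives 97%, a large upward step is expected for compound 4, estimated as a number 78.6 percentage points higher from compound 1 to compound 4 (beyond the scatter). Compound 4 is therefore expected at 80%, within 40% to 99%.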

Compound 4, a percentage reported as inhibition, at one concentration (the size of the read-out at that concentration, not a potency): 87.6%
For compound 4 the middle estimate is 7.6 percentage points below the measured one, and the stated range covers the measured number.
By their numbers in this assay, from the lowest: compound 1; then compounds 4, 2 and 3 (each within the scatter of the next, the first and the last beyond it).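

In this assay, within the data shown here, the change from phenyl to 1-acetyl-1H-pyrazol-3-yl gives a number 86.2 percentage points higher from compound 1 to compound 4 (beyond the scatter), the first step in which this swap stands alone on the shared core. It shows that the group on this aromatic carbon, meta to a large group, can by itself carry the read-out from almost nothing to a high level. Nothing available explains this step. Going by these compounds, it remains open whether the acetyl group matters here, and whether a plain 1H-pyrazol-3-yl, or a phenyl bearing an amine or a carboxylic acid, would give a similar number at this place.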